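A few compounds are considered here, and "the series" means these few. Any claim that something is new, unique, unknown or untested is made for them only; others in the source may bear on it.

Compound 1 `CCN(CC)CN1C(=O)/C(=N/NC(=S)Nc2ccc(OC)cc2)c2ccccc21`: 2400 nM
Compound 2 `CCN(CC)CN1C(=O)/C(=N/NC(=S)Nc2ccccc2)c2ccccc21`: 13000 nM

In a functional assay on L1210 cells (Mus musculus) for inhibition, read by cell counting, with a stated time of 48 h (on this read-out higher numbers stand for weaker inhibition and lower numbers for stronger inhibition), compound 2 gives 13000 nM, the higher of the two numbers, while compound 1 gives 2400 nM. The next compound, compound 3 `CCN(CC)CN1C(=O)/C(=N/NC(=S)Nc2ccc(C)cc2)c2ccccc21`, departs from compound 2 by one change: methyl in place of hydrogen on an aromatic carbon. Within the data shown here, only one measured step bears on this, a 5.4-fold higher number from compound 1 to compound 2 (0.73 log units; beyond the scatter), a modest step beyond the scatter that comes from hydrogen in place of methoxy on an aromatic carbon. Read in reverse, it shows a group gained with a lower number. Among the measured compounds shown here, no measured compound carries methyl, so this is thin support. A lower number than that of compound 2 is expected, by a smaller margin than this one step. The expected change is a 2.4-fold lower number from compound 2 to compound 3 (0.37 log units; beyond the scatter). For compound 3 the estimated value is 5500 nM, with an expected range of 2200 nM to 13000 nM.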

Compound 3, half-maximal inhibitory concentration: 29000 nM
The estimate for compound 3 lay 5.3-fold (0.72 log units) below the measured number; the whole stated range lies below it.
By their numbers in this assay, from the lowest: compound 1; then compound 2; then compound 3.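

In this assay, the aromatic carbon para to a large group does not respond to any added group in the same way. Methyl in place of hydrogen raises the number (a 2.2-fold higher number from compound 2 to compound 3 (0.35 log units; beyond the scatter)), whereas the earlier step (a 5.4-fold higher number from compound 1 to compound 2 (0.73 log units; beyond the scatter)) showed that compound 1, with methoxy, has the lower number. Methoxy and methyl are therefore far apart at this one position (a 12-fold higher number from compound 1 to compound 3 (1.08 log units; beyond the scatter)), with hydrogen falling between them, and nothing measured here explains this difference.

From the compounds shown here alone, whether an ethoxy group would stay close to methoxy, or an ethyl group close to methyl, remains open. So does where a chlorine atom, a hydroxyl or an amine on this carbon would fall in the order of these three compounds.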